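The source may report more compounds than this note shows. Statements on the series, on what has been measured and on what is new or still open speak of the compounds shown alone.

All three measured compounds were tested in a functional assay on KBVIN cells (Homo sapiens) for antiproliferative activity, read by sulforhodamine B assay, with a stated time of 3 days; on this read-out lower numbers stand for an effect already at smaller amounts and higher numbers for an effect only at larger amounts of compound:

Compound 1 `CCC1=C(O)c2c(oc(-c3cccc(F)c3)cc2=O)C(CC)(CC)C1=O` gives 3.09 uM
Compound 2 `CCC1=C(O)c2c(oc(-c3ccccc3C)cc2=O)C(CC)(CC)C1=O` gives 2.41 uM
Compound 3 `CCC1=C(O)c2c(oc(-c3cc(C)c(C)cc3C)cc2=O)C(CC)(CC)C1=O` gives 4.37 uM

Compound 3 carries the highest of the three numbers, yet its separation from the others is small: a 1.4-fold higher number from compound 1 to compound 3 (0.15 log units; within the scatter) and a 1.8-fold higher number from compound 2 to compound 3 (0.26 log units; within the scatter) both stay within the scatter, so no order among the three can be claimed. The unmeasured compound 4 `CCC1=C(O)c2c(oc(-c3cc(C)ccc3F)cc2=O)C(CC)(CC)C1=O` arises from compound 3 by a single change on the aryl group: 2-fluoro-5-methylphenyl in place of 2,4,5-trimethylphenyl on an aromatic carbon.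

Every measured step here exchanges one aryl group for another on the same aromatic carbon of the shared core, and none of them moved the number beyond the scatter: a 1.3-fold lower number from compound 1 to compound 2 (0.11 log units; within the scatter), a 1.4-fold higher number from compound 1 to compound 3 (0.15 log units; within the scatter) and a 1.8-fold higher number from compound 2 to compound 3 (0.26 log units; within the scatter). Compound 1 already carries a fluorine on that ring, and compound 2 and compound 3 carry methyl groups, so both kinds of substituent that compound 4 combines are represented among compounds whose values lie close together. For compound 4 a step of no more than the usual scatter is therefore expected in this assay, if anything toward a somewhat lower number, in line with compound 1 and compound 2. The estimated step is a 1.5-fold lower number from compound 3 to compound 4 (0.16 log units; within the scatter). Compound 4 is expected to give 3 uM, with a range from 1.5 uM to 6 uM.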

Compound 4, concentration for half-maximal effect: 3.24 uM
Compound 4: the middle estimate sits 1.1-fold (0.03 log units) below what was measured; low and high end bracket the measured number.
By their numbers in this assay, from the lowest: compounds 2, 1, 4 and 3 (each within the scatter of the next).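

In this assay, the aromatic carbon next to the ring oxygen now also carries a ring with both fluorine and methyl, and the number stays within the scatter of all three earlier compounds. Putting 2-fluoro-5-methylphenyl in place of 2,4,5-trimethylphenyl gives a 1.3-fold lower number from compound 3 to compound 4 (0.13 log units; within the scatter), in place of 2-methylphenyl it gives a 1.3-fold higher number from compound 2 to compound 4 (0.13 log units; within the scatter), and in place of 3-fluorophenyl it gives a 1.0-fold higher number from compound 1 to compound 4 (0.02 log units; within the scatter), so no step among these four aryl groups leaves the scatter. Nothing measured here offers a reason for this flat picture.

Going by these compounds, all four aryl groups are phenyl rings bearing only fluorine or methyl, so it remains open whether a carboxylic acid or an amine on that ring, or a longer chain such as hexyl in place of methyl, would move the number beyond the scatter. The ethyl groups on the shared core are the same throughout, so these compounds also leave open what replacing them, for instance with methyl groups, would do.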